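Working notes: from 4-fluorobenzyl to 2-methylbenzyl

A few compounds are considered here, and "the series" means these few. Any claim that something is new, unique, unknown or untested is made for them only; others in the source may bear on it.

Values in an ADME assay on L929 cells (Mus musculus) for cytotoxicity, read by microscopy, with a stated time of 96 h (on this read-out higher numbers stand for lower toxicity in this test and lower numbers for higher toxicity in this test), so far
compound 1 `Cc1n[nH]c2c1[C@@H](c1ccc(OCc3ccc(Cl)cc3)cc1)S[C@@H](C)C(=O)N2` gives "not determined" (no result reported)
compound 2 `Cc1n[nH]c2c1[C@@H](c1ccc(OCc3cccc(F)c3)cc1)S[C@@H](C)C(=O)N2` gives 103000 nM
compound 3 `Cc1n[nH]c2c1[C@@H](c1ccc(OCc3ccc(F)cc3)cc1)S[C@@H](C)C(=O)N2` gives "not determined" (no result reported)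

Compound 3 has no single number in this assay and so cannot be placed on the scale. For the measured compounds named here, compound 1 has no number either, which leaves compound 2 (103000 nM) as the only quantitative reading. The next compound to be read is compound 4 `Cc1ccccc1COc1ccc([C@H]2S[C@@H](C)C(=O)Nc3[nH]nc(C)c32)cc1` with the same core. The structural change is 2-methylphenyl in place of 4-fluorophenyl on a saturated chain carbon bound to an oxygen on an aromatic ring. Going by the values given here, no measured pair shows what a change of this kind does here, so the direction is open and no step beyond the usual scatter is expected. The expectation rests on compound 2 (103000 nM) alone, and the range is kept wide for that reason. Compound 4 is expected at 100000 nM (estimated range 40000 nM to 250000 nM).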

Compound 4, concentration lethal to 50% of the cells: 111000 nM
Estimate against measurement, compound 4: 1.1-fold (0.05 log units) below; low and high end bracket the measured number.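

In this assay, the place on a saturated chain carbon bound to an oxygen on an aromatic ring now has a second reading, with a 1.1-fold higher number from compound 2 to compound 4 (0.03 log units; within the scatter), so 2-methylphenyl and 3-fluorophenyl read alike there. Steps to or from compound 1 and compound 3 cannot be read, as neither has a number, and the change from 4-fluorobenzyl to 2-methylbenzyl therefore stays without a direct comparison. No supporting data bear on this result. 

Left open is whether an amine, a carboxylic acid or a longer chain at this place would give a number beyond the scatter. For the compounds shown here, with only two numbers, it is also open whether the shared core or this place governs the read-out.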